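Methoxy in Place of Cyano on the Phenyl Ring

The source may report more compounds than this note shows. Statements on the series, on what has been measured and on what is new or still open speak of the compounds shown alone.

Measured compounds:
compound 1, `CC1(C)[C@H]2CC[C@]1(C)N(Cc1cn(-c3ccccc3C#N)nn1)C(=O)C2`, 240 nM
compound 2, `CC1(C)[C@H]2CC[C@]1(C)N(Cc1cn(-c3cccc(C#N)c3)nn1)C(=O)C2`, 260 nM
compound 3, `CC1(C)[C@H]2CC[C@]1(C)N(Cc1cn(-c3ccccc3F)nn1)C(=O)C2`, 150 nM

All three share one core and differ only in the substituted phenyl ring attached to the aromatic nitrogen. In a functional assay on PANC-1 cells (Homo sapiens) for inhibition, read by MTT assay, with a stated time of 24 h (a lower number here means a stronger inhibitor, a higher number a weaker inhibitor), compound 1 gives 240 nM, the second highest of the three numbers. Its closest neighbour is compound 2, with a 1.1-fold higher number from compound 1 to compound 2 (0.03 log units; within the scatter); compound 3 lies furthest away, with a 1.6-fold lower number from compound 1 to compound 3 (0.20 log units; within the scatter). Both steps stay within the scatter, so the three compounds cannot be ranked against one another.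

Compound 4, `COc1ccccc1-n1cc(CN2C(=O)C[C@@H]3CC[C@@]2(C)C3(C)C)nn1`, has not yet been measured. It differs from compound 1 in one place: methoxy in place of cyano on an aromatic carbon.

Going by the values given here, the step that bears most on this change is the one from compound 1 to compound 3, where fluoro replaced cyano on the same aromatic carbon and the number moved by a 1.6-fold lower number from compound 1 to compound 3 (0.20 log units; within the scatter). Moving the cyano group instead, from compound 1 to compound 2, gave a 1.1-fold higher number from compound 1 to compound 2 (0.03 log units; within the scatter). Among the compounds with values here, every change tried so far on this ring has stayed within the scatter, and no methoxy analogue exists to indicate otherwise. The step from compound 1 to compound 4 is therefore expected to be small, a 1.2-fold lower number from compound 1 to compound 4 (0.08 log units; within the scatter). For compound 4 in this assay the estimate is 200 nM, with a range from 90 nM to 450 nM.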

Compound 4, half-maximal inhibitory concentration: 120 nM
Beside the measured number, compound 4's estimate is 1.7-fold (0.22 log units) above it; measured number inside the range.
By their numbers in this assay, from the lowest: compounds 4, 3, 1 and 2 (each within the scatter of the next, the first and the last beyond it).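

In this assay, going by these compounds alone, the 2-methoxyphenyl group gives the first pair in this set that stands apart beyond the scatter, though only modestly: a 2.2-fold lower number from compound 2 to compound 4 (0.34 log units; beyond the scatter). That step changes both the group and where it sits on the ring, so it cannot be credited to methoxy alone, and the direct swap on the same aromatic carbon stays within the scatter, at a 2.0-fold lower number from compound 1 to compound 4 (0.30 log units; within the scatter), as does the exchange with fluoro, at a 1.3-fold lower number from compound 3 to compound 4 (0.10 log units; within the scatter); compounds 1, 3 and 4 therefore still cannot be ranked against one another. No measurement offered here explains any of these numbers.

Going by these compounds, it remains open whether another group on this aromatic carbon, such as an ethoxy chain, a hydroxyl or an amine, would separate clearly from the 2-cyanophenyl compound. All four compounds also keep the shared core unchanged, so these results say nothing about how the number responds to changes made there.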